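The compounds below may be only part of what the source reports. "The series", "measured", "known", "first", "only" and "open" are said of these compounds alone.

In an ADME assay on HepG2 cells (Homo sapiens) for cytotoxicity, read by resazurin assay, with a stated time of 24 h (on this read-out lower numbers stand for higher toxicity in this test and higher numbers for lower toxicity in this test), the compounds of this series sit at the weakly toxic end. Compound 1, `COc1cccc(C=Cc2ccc3ccccc3c2)c1C(=O)O`, gives only a limit of the assay in this assay, > 100000 nM, and no number; it is one of the values described by the limit of > 100000 nM in this assay, at which 1 of the 3 values shown sits. Its demethylated relative compound 2, `O=C(O)c1c(O)cccc1C=Cc1ccc2ccccc2c1`, gives 71000 nM in this assay, and the saturated analogue compound 3, `Cc1cc(O)c(C(=O)O)c(CCc2ccc3ccccc3c2)c1`, gives 38000 nM. The one single-change step among these, an at least 1.4-fold lower number from compound 1 to compound 2 (0.14 log units; that floor lies within the scatter), is the only measured step, and it concerns a hydrogen in place of methyl on an oxygen on an aromatic ring, not a halogen.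

Compound 4, `COc1cc(Cl)cc(C=Cc2ccc3ccccc3c2)c1C(=O)O`, differs from compound 1 by chloro in place of hydrogen on an aromatic carbon. For the measured compounds named here, no measured step touches this kind of change, so the expectation rests on the position of compound 1 alone. Since compound 1 gives > 100000 nM in this assay, a limit, compound 4 is expected to stay near the same region, with a step of an at least 1.1-fold lower number from compound 1 to compound 4 (0.04 log units; that floor lies within the scatter) that is not expected to exceed the scatter. The estimate for compound 4 in this assay is 90000 nM, within a range from 40000 nM to 200000 nM.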

Compound 4, half-maximal cytotoxic concentration: 104000 nM
Beside the measured number, compound 4's estimate is 1.2-fold (0.06 log units) below it, within the range that was stated.
By their numbers in this assay, from the lowest: compounds 3, 2 and 4 (each within the scatter of the next, the first and the last beyond it).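

The step from compound 1 to compound 4 cannot be read, because compound 1 carries a limit and no number: the limit of > 100000 nM in this assay, at which 1 of the 4 values shown sits.

The compounds shown leave open what chloro in place of hydrogen on an aromatic carbon does to this read-out: no pair with a number at both ends carries that change.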